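Dropping the chloro: compound 4 against its chloro parent

The source may report more compounds than this note shows. Statements on the series, on what has been measured and on what is new or still open speak of the compounds shown alone.

Measured compounds:
compound 1 `Cc1ccc(-c2nc(CNc3ccc(C(=O)NO)cc3)n(-c3ccccc3)n2)cc1` — 224 nM
compound 2 `O=C(NO)c1ccc(NCc2nc(-c3ccc(Cl)cc3)nn2-c2ccccc2)cc1` — 181 nM
compound 3 `O=C(NO)c1ccc(NCc2nc(-c3ccccc3)nn2-c2cccc(Cl)c2)cc1` — 678 nM

In an assay on Sf9 cells for inhibition of protein deacetylase HDAC6 (Homo sapiens), read by fluorescence, with a stated time of 40 min (a lower number here means a stronger inhibitor, a higher number a weaker inhibitor), compound 2 gives the lowest number of the three. Compound 1 lies within the scatter of it, while compound 3 gives a number beyond the scatter above it. Going by the values given here, the single step that can be traced is a 1.2-fold lower number from compound 1 to compound 2 (0.09 log units; within the scatter), so swapping chloro for methyl on that aromatic carbon changed little. Compound 4 `O=C(NO)c1ccc(NCc2nc(-c3ccccc3)nn2-c2ccccc2)cc1` is not yet measured; it differs from compound 2 by hydrogen in place of chloro on an aromatic carbon. Among the compounds with values here, no measured pair shows the loss of a substituent at that carbon, so the expectation rests on the methyl and chloro analogues, compound 1 and compound 2, which sit close together. The substituent-free ring of compound 4 is expected to give a somewhat higher number, estimated as a 1.7-fold higher number from compound 2 to compound 4 (0.22 log units; within the scatter). For compound 4 the estimate in this assay is 300 nM, with a range from 150 nM to 700 nM.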

Compound 4, half-maximal inhibitory concentration: 112 nM
Estimate against measurement, compound 4: 2.7-fold (0.43 log units) above; measured number below the stated range.
By their numbers in this assay, from the lowest: compounds 4, 2 and 1 (each within the scatter of the next); then compound 3.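

In this assay the unsubstituted phenyl shows that this carbon, para to a large group, does not need a substituent: the change gives a 1.6-fold lower number from compound 2 to compound 4 (0.21 log units; within the scatter) and the methyl counterpart gives a 2.0-fold lower number from compound 1 to compound 4 (0.30 log units; within the scatter), so hydrogen, chloro and methyl cannot be told apart here. The same exchange with the chloro at its other place in the series gives a 6.1-fold lower number from compound 3 to compound 4 (0.78 log units; beyond the scatter), so among these compounds the size of this change depends on where the chloro stands. Nothing measured here accounts for that difference between the two places. The compounds shown leave open how an amine or a carboxylic acid on this carbon would read, since only hydrogen, chloro and methyl appear there. Also open, on these data alone, is whether a methyl in place of the chloro of compound 3 would behave as that chloro does.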